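The source may hold more compounds than are shown below. What is called first, only, known or untested is meant among the compounds shown, and "the series" means these compounds.

Working notes on the hydrazone series built on the shared core of compound 1 `CCCSc1nc(N/N=C/c2ccc(Cl)cc2)c2nnn(Cc3ccccc3)c2n1`. In a functional assay on MCF7 cells (Homo sapiens) for antiproliferative activity, read by MTT assay, with a stated time of 72 h (a higher number here means a weaker inhibitor, a lower number a stronger inhibitor), compound 1 gives > 64000 nM, which is a limit of the assay and not a number. Compound 2 `CCCSc1nc(N/N=C/c2ccc(N(C)C)cc2)c2nnn(Cc3ccccc3)c2n1` gives 12200 nM in this assay. Compound 3 `CCCSc1nc(N/N=C/c2ccccc2)c2nnn(Cc3ccccc3)c2n1` gives > 64000 nM in this assay, again a limit rather than a number, so compound 3 stands at the edge of what this assay reports, together with compound 1 (the limit of > 64000 nM in this assay, at which 2 of the 3 values shown sit). The step from the dimethylamino compound to the unsubstituted phenyl is readable as an at least 5.2-fold higher number from compound 2 to compound 3 (0.71 log units; beyond the scatter), whereas a step that the two limits leave unreadable from compound 1 to compound 3 cannot be sized. Compound 4 `CCCSc1nc(N/N=C/c2ccc([N+](=O)[O-])cc2)c2nnn(Cc3ccccc3)c2n1` differs from compound 3 by nitro in place of hydrogen on an aromatic carbon. Of the steps seen, the two that bear on a para substituent are those just named; only the dimethylamino group has given a number, the chloro group and hydrogen have not. A step of the size an at least 1.6-fold lower number from compound 3 to compound 4 (0.20 log units; that floor lies within the scatter) is therefore expected from compound 3 to compound 4 in this assay, with considerable doubt as to direction. Compound 4 is expected to give about 40000 nM, somewhere between 8000 nM and 150000 nM.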

Compound 4, half-maximal inhibitory concentration: 11000 nM
Estimate against measurement, compound 4: 3.6-fold (0.56 log units) above; the range from low to high includes it.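

Nitro at this position on the phenyl ring gives an at least 5.8-fold lower number from compound 3 to compound 4 (0.76 log units; beyond the scatter) in this assay, so a measurable value at this place is no longer tied to the dimethylamino group alone. The same holds against the chloro group, with an at least 5.8-fold lower number from compound 1 to compound 4 (0.76 log units; beyond the scatter). Nitro and dimethylamino cannot be told apart here, with a 1.1-fold lower number from compound 2 to compound 4 (0.04 log units; within the scatter), so two groups with quite different atoms give the same reading, while chloro and hydrogen go against any simple rule that a group at this place brings a value within the range of this assay.

Compound 1 and compound 3 stay at the edge of what is reported, and their order cannot be read: the limit of > 64000 nM in this assay, at which 2 of the 4 values shown sit. As far as these compounds go, whether a methoxy group, a nitrile or a carboxylic acid at this place would go beyond compound 2 and compound 4 stays open.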